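A Larger Ester Group in Place of a Two-Atom Chain

The source may report more compounds than this note shows. Statements on the series, on what has been measured and on what is new or still open speak of the compounds shown alone.

Compound 3 `[C-]#[N+]Cc1c(C)nc2c(OCc3ccccc3)cccn12` stands highest of the three compounds measured in a functional assay on the whole organism with Rattus norvegicus as the target, with a stated time of 4 h, at a dose of 40 mg/kg by the intraperitoneal route; a lower number here means less inhibition, a higher number more inhibition at the dose given (going by the name of the read-out): compound 3 gives 96%. Compound 1 `Cc1cn2cccc(OCc3ccccc3)c2n1` gives 62%, and compound 2 `Cc1nc2c(CSc3ccccc3)cccn2c1C` gives 29%. Compound 4 `Cc1nc2c(OCc3ccccc3)cccn2c1COC(=O)c1cccnc1` differs from compound 3 by a group of 9 heavy atoms (6 carbon, 1 nitrogen, 2 oxygen; one six-membered aromatic ring with 1 hetero atom) in place of a group of 2 heavy atoms (1 carbon, 1 nitrogen; no ring), on a saturated chain carbon bound to an aromatic carbon. Among the compounds with values here, the only measured step that bears on this part of the core is a number 34 percentage points higher from compound 1 to compound 3 (beyond the scatter), a large gain when the group carrying this chain was introduced. Within the data shown here, no measured step removes or exchanges the chain itself, so the size of this step is uncertain; a moderate fall is expected. Compound 4 is therefore estimated to give 75%, within a range from 45% to 98%. The expected step is a number 21 percentage points lower from compound 3 to compound 4 (beyond the scatter).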

Compound 4, a percentage reported as inhibition, in the whole organism at one dose (the size of the read-out at that dose, not a potency): 87%
Compound 4: middle estimate off by 12 percentage points, on the low side, and the stated range covers the measured number.
By their numbers in this assay, from the lowest: compound 2; then compound 1; then compounds 4 and 3 (each within the scatter of the next).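

Exchanging the group of 2 heavy atoms for ((pyridin-3-yl)carbonyl)oxy, on a saturated chain carbon bound to an aromatic carbon, gives a number 9 percentage points lower from compound 3 to compound 4 (within the scatter) in this assay. This position therefore accepts a much larger group, with a ring and hydrogen-bond acceptors, without a change beyond the scatter. No measurement given here accounts for this result.

On these data alone, what an amine or a carboxylic acid on this chain carbon would give in this assay remains open. So does whether the pyridin-3-yl ring matters, a question a plain benzoyl ester would address.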